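The source may report more compounds than this note shows. Statements on the series, on what has been measured and on what is new or still open speak of the compounds shown alone.

The account takes in two measured compounds and one that still awaits measurement. Compound 1 `NCCCCN(C[C@@H]1Cc2nccnc2CN1)[C@H]1CCCc2cccnc21` gives 67% in an ADME assay on microsomes from liver (Rattus norvegicus) for metabolic stability, using NADPH, with a stated time of 10 min; a higher number here means that more of the compound is left, a lower number that less of the compound is left. Compound 2 `CN(C[C@H]1Cc2ncccc2CN1)[C@H]1CCCc2cccnc21` gives 7% in this assay, the lowest of the two numbers; compound 1 stands beyond the scatter above it. Among the measured compounds shown here, the two compounds differ in more than one place, so the pair itself gives no single step to lean on.

Compound 3 `CN(C)CCCCN(C[C@H]1Cc2ncccc2CN1)[C@H]1CCCc2cccnc21` is the next compound, and it differs from compound 2 in one way: 3-(dimethylamino)propyl in place of hydrogen on a saturated chain carbon bound to an amine nitrogen. For the measured compounds named here, no step between measured compounds covers this change. Still, compound 1 carries a longer chain at the same amine nitrogen and gives 67%, which suggests an upward step beyond the scatter is to be expected, though compound 1 also differs in its core. The expected step in this assay is a number 28 percentage points higher from compound 2 to compound 3 (beyond the scatter). Compound 3 is therefore estimated to give 35% in this assay, with a range from 12% to 65%.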

Compound 3, percent of the compound remaining: 27%
The estimate for compound 3 lay 8 percentage points above the measured number; low and high end bracket the measured number.
By their numbers in this assay, from the lowest: compound 2; then compound 3; then compound 1.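

In this assay, among the compounds shown here, 3-(dimethylamino)propyl in place of hydrogen on a saturated chain carbon bound to an amine nitrogen gives a number 20 percentage points higher from compound 2 to compound 3 (beyond the scatter) and so provides the first single-change step in this set. Read one bond further out, as methyl to 4-(dimethylamino)butyl, the change shows that this amine nitrogen can carry the longer chain with more of the compound left, not less, on the core shared by these two compounds. Nothing measured here explains the size or direction of this step. The compounds shown leave open whether a shorter chain, or a chain ending in a carboxylic acid or a hydroxyl group instead of dimethylamino, would give a similar number. They also leave open whether the same change would give a similar step on the core of compound 1.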